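Moving a Methoxy Group Across a Biaryl Sulfonamide

A few compounds are considered here, and "the series" means these few. Any claim that something is new, unique, unknown or untested is made for them only; others in the source may bear on it.

Compound 1 `COc1ccccc1-c1cccc(S(=O)(=O)N2CCC(N3CCC(C)CC3)CC2)c1`: 21 nM
Compound 2 `Cc1cc(C)c(S(=O)(=O)N2CCC(C3OCC(C)CO3)CC2)c(C)c1`: > 5000 nM
Compound 3 `CC1CCN(C2CCN(S(=O)(=O)c3ccc(OCc4ccccc4)cc3)CC2)CC1`: 385 nM

All three were tested in a functional assay on DLD-1 cells (Homo sapiens) for antiproliferative activity, read by CellTiter-Glo, with a stated time of 72 h; on this read-out higher numbers stand for weaker inhibition and lower numbers for stronger inhibition. Compound 1 has the lowest of the two numbers obtained; the nearest, compound 3, sits well above it, a gap beyond the usual scatter. In this assay compound 2 gives only a limit, > 5000 nM, not a number.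

Compound 4 `COc1ccc(-c2cccc(S(=O)(=O)N3CCC(N4CCC(C)CC4)CC3)c2)cc1` has not yet been measured. It differs from compound 1 by 4-methoxyphenyl in place of 2-methoxyphenyl on an aromatic carbon. Within the data shown here, no measured pair shows the effect of this change, so the expectation rests on compound 1 alone. A modest weakening, beyond the scatter, is expected, a 2.9-fold higher number from compound 1 to compound 4 (0.46 log units; beyond the scatter). Compound 4 is therefore estimated at 60 nM, most likely between 15 nM and 250 nM.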

Compound 4, half-maximal inhibitory concentration: 23 nM
Estimate against measurement, compound 4: 2.6-fold (0.42 log units) above; low and high end bracket the measured number.
By their numbers in this assay, from the lowest: compounds 1 and 4 (each within the scatter of the next); then compound 3. At a limit, above all of these: compound 2.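

In this assay, 4-methoxyphenyl in place of 2-methoxyphenyl gives a 1.1-fold higher number from compound 1 to compound 4 (0.04 log units; within the scatter), so the two placements of the methoxy group cannot be told apart. Among these compounds, this is the first direct comparison at this position, and it shows that the change leaves the strong activity of compound 1 intact. Potency here therefore does not depend on which of these two methoxyphenyl groups is present.

Going by these compounds, what a plain phenyl, a hydroxyl or an amine would do at this position remains open. Nothing shown explains why the two groups match.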